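The compounds below may be only part of what the source reports. "The series", "measured", "known", "first", "only" and "open" are said of these compounds alone.

Measured compounds:
- compound 1 `O=c1[nH]c(-c2c[nH]nc2-c2ccccc2)nc2ccccc12`: "not determined" (no result reported)
- compound 2 `Cc1cc(Br)cc2c1NC(c1c[nH]nc1-c1cccc3ccccc13)NC2=O`: 3700 nM
- compound 3 `Cc1cc(Cl)cc2c1NC(c1c[nH]nc1-c1ccc(Br)cc1)NC2=O`: "not determined" (no result reported)

Going by the values given here, in an assay on HEK293 cells for inhibition of transient receptor potential cation channel subfamily M member 2 (Homo sapiens), read by patch clamp, with a stated time of 60 s (on this read-out lower numbers stand for stronger inhibition and higher numbers for weaker inhibition), compound 2 gives 3700 nM and is the only compound of the set with a number. For compound 3 the outcome in this assay is "not determined" (no result reported), so compound 3 stands without a value of its own, and compound 1 likewise has none. Compound 4 `Cc1cc(Cl)cc2c1NC(c1c[nH]nc1-c1ccccc1)NC2=O` has not been measured. The change from compound 3 to compound 4 is hydrogen in place of bromo on an aromatic carbon, leaving the rest of the structure untouched. Among the compounds with values here, no step between measured compounds is available, so the size and direction of this step in this assay cannot be read from the data. Since the same six-membered aromatic ring of carbon only carries a bromo group in compound 3 and nothing in compound 4, and no comparison with a number exists for it, an effect no larger than the usual scatter is expected, in either direction. Compound 4 is therefore expected to give about 5000 nM in this assay, with a range from 1000 nM to 30000 nM.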

Compound 4, half-maximal inhibitory concentration: 5100 nM
Compound 4: middle estimate off by 1.0-fold (0.01 log units), on the low side; the measured number falls inside the stated range.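

In this assay, going by these compounds alone, compound 4 gives 5100 nM while compound 3 has "not determined" (no result reported) and so no step between these two compounds can be read. The compounds shown leave open what the change from 4-bromophenyl to phenyl does to this inhibition. No evidence bears on this result.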